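Methoxy to hydroxy on the aryl group of compound 3

A few compounds are considered here, and "the series" means these few. Any claim that something is new, unique, unknown or untested is made for them only; others in the source may bear on it.

Within the data shown here, compound 3 `COc1cc(-c2nn(-c3cccc(NC(=O)Nc4ccc(Cl)c(C(F)(F)F)c4)c3)cc2-c2ccncc2)ccc1Cl` gives the only number among the three measured compounds, 21500 nM in a functional assay on HCT-116 cells (Homo sapiens) for inhibition, read by sulforhodamine B assay, with a stated time of 48 h; a lower number here means that less compound is tolerated, a higher number that more compound is tolerated. Compound 1 `O=C(Nc1cccc(-n2cc(-c3ccncc3)c(-c3ccc(Cl)c(O)c3)n2)c1)Nc1cccc(C(F)(F)F)c1` sits at a limit of this assay, > 32500 nM. Compound 2 `O=C(Nc1cccc(-n2cc(-c3ccncc3)c(-c3ccc(Cl)c(O)c3)n2)c1)Nc1ccc(Cl)c(Cl)c1` likewise sits at a limit, > 32500 nM. Among the measured compounds shown here, the single measured step, a step that the two limits leave unreadable from compound 1 to compound 2, concerns a different place and offers no guide here. Compound 4 `O=C(Nc1cccc(-n2cc(-c3ccncc3)c(-c3ccc(Cl)c(O)c3)n2)c1)Nc1ccc(Cl)c(C(F)(F)F)c1` differs from compound 3 by hydrogen in place of methyl on an oxygen on an aromatic ring. Both compounds that carry the hydroxy group stand at the limit of > 32500 nM in this assay, at which 2 of the 3 values shown sit, so this change is expected to move compound 4 towards that limit. Compound 4 is expected to give 32000 nM, within 12000 nM to 90000 nM. The step from compound 3 to compound 4 is therefore estimated as a 1.5-fold higher number from compound 3 to compound 4 (0.17 log units; within the scatter).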

Compound 4, concentration lethal to 50% of the cells: > 32500 nM
Compound 4 was reported as a limit; the forecaster's own chance of this, stated with the estimate: 55%; middle value at least 1.0-fold (0.00 log units) away from the limit.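

In this assay, among these compounds, the first direct comparison at this position, methoxy to hydroxy on the aryl group gives an at least 1.5-fold higher number from compound 3 to compound 4 (0.17 log units; that floor lies within the scatter), and the true step may be larger. Compounds 1, 2 and 4, all carrying the hydroxy group, now stand at one limit of the assay rather than at a number: the limit of > 32500 nM in this assay, at which 3 of the 4 values shown sit. The steps among these three compounds cannot be read, since each end is a limit.

As far as these compounds go, how far compound 4 lies past that limit remains open. So does whether an amine or a carboxylic acid at this position would give a readable number.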